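One Fluorine Relocated: What Should Compound 3 Do?

The source may report more compounds than this note shows. Statements on the series, on what has been measured and on what is new or still open speak of the compounds shown alone.

Compound 1 `COc1ccc(NC(=O)COc2cc(/C=C/C(=O)NO)ccc2OC)cc1`: 3810 nM
Compound 2 `COc1ccc(/C=C/C(=O)NO)cc1OCC(=O)Nc1ccccc1F`: 15600 nM

In a functional assay on MDA-MB-231 cells (Homo sapiens) for inhibition, read by MTT assay, with a stated time of 48 h (on this read-out higher numbers stand for weaker inhibition and lower numbers for stronger inhibition), compound 2, at 15600 nM, has the higher of the two numbers, making it the weaker inhibitor. Compound 3 `COc1ccc(/C=C/C(=O)NO)cc1OCC(=O)Nc1cccc(F)c1` has the same atoms, joined differently: 3-fluorophenyl in place of 2-fluorophenyl on an amide-type nitrogen. Among the measured compounds shown here, the only measured step, a 4.1-fold higher number from compound 1 to compound 2 (0.61 log units; beyond the scatter), exchanged a different group and was modest, so no measurement yet tests this change directly. Only a small shift toward a lower number is therefore expected. The expected change is a 1.6-fold lower number from compound 2 to compound 3 (0.19 log units; within the scatter). For compound 3, the estimated value is 10000 nM, with an expected range of 4000 nM to 25000 nM.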

Compound 3, half-maximal inhibitory concentration: 3410 nM
Beside the measured number, compound 3's estimate is 2.9-fold (0.47 log units) above it; the whole stated range lies above it.
By their numbers in this assay, from the lowest: compounds 3 and 1 (each within the scatter of the next); then compound 2.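

In this assay, relocating a single fluorine is enough to move the result: a 4.6-fold lower number from compound 2 to compound 3 (0.66 log units; beyond the scatter). On the amide-type nitrogen, then, it matters where the fluorine sits on the phenyl ring, not only which group is attached. With a 1.1-fold lower number from compound 1 to compound 3 (0.05 log units; within the scatter), 3-fluorophenyl and 4-methoxyphenyl cannot be told apart here, and no supporting data explain the effect of the fluorine's place. Going by these compounds, whether an amine or a carboxylic acid on that phenyl ring would give a similar number stays open, and so does the effect of a longer chain between the amide and the ring.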